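The source may hold more compounds than are shown below. What is called first, only, known or untested is meant among the compounds shown, and "the series" means these compounds.

Series measured in a functional assay on MOLT-4 cells (Homo sapiens) for antiproliferative activity, with a stated time of 48 h; a lower number here means a stronger inhibitor, a higher number a weaker inhibitor:
- compound 1 `C=C(Br)C(=O)Nc1ccc(C(=O)/C=C/c2ccccc2)cc1`: 500 nM
- compound 2 `C=C(Br)C(=O)Nc1ccc(C(=O)/C=C/c2ccc(OC)cc2)cc1`: 610 nM
- compound 3 `C=C(Br)C(=O)Nc1ccc(C(=O)/C=C/c2ccc(OC)cc2OC)cc1`: 1500 nM

Compound 2 gives 610 nM, which lies within the scatter of compound 1, while compound 3 has the highest number of the set. The next entry is compound 4 `C=C(Br)C(=O)Nc1ccc(C(=O)/C=C/c2ccc(N(C)C)cc2)cc1`, which differs from compound 2 as follows: dimethylamino in place of methoxy on an aromatic carbon. This places dimethylamino in place of methoxy on an aromatic carbon, para to a large group.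

Going by the values given here, no measured step makes this exact exchange, so the evidence is indirect. The closest step is the one that introduces the methoxy of compound 2 at the carbon now being changed: a 1.2-fold higher number from compound 1 to compound 2 (0.09 log units; within the scatter). Replacing hydrogen with methoxy at this carbon therefore produced no change beyond the scatter. The other step adds a further methoxy to the same ring: a 2.5-fold higher number from compound 2 to compound 3 (0.39 log units; beyond the scatter). It shows that substitution on this ring can shift the number modestly, but it involves a different carbon and bears less directly on compound 4.

No shift beyond the scatter is therefore expected in this assay, and no direction is favoured. The expected change is a 1.0-fold lower number from compound 2 to compound 4 (0.01 log units; within the scatter). For compound 4 the expected value is 600 nM, with an estimated range of 250 nM to 1500 nM.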

Compound 4, half-maximal inhibitory concentration: 1300 nM
Compound 4: middle estimate off by 2.2-fold (0.34 log units), on the low side; the range from low to high includes it.
By their numbers in this assay, from the lowest: compounds 1 and 2 (each within the scatter of the next); then compounds 4 and 3 (each within the scatter of the next).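

The carbon para to a large group is not indifferent to its substituent: hydrogen and methoxy there could not be told apart, but dimethylamino in place of methoxy gives a 2.1-fold higher number from compound 2 to compound 4 (0.33 log units; beyond the scatter) in this assay. The same substituent also separates from the unsubstituted parent, with a 2.6-fold higher number from compound 1 to compound 4 (0.41 log units; beyond the scatter), so both reference points at this carbon now show a modest loss, and the tolerance seen for methoxy does not extend to every group placed there. Going by these compounds alone, this is the first single-place change at this carbon to move the number beyond the scatter, and nothing available on the compounds accounts for the difference between methoxy and dimethylamino.

The compounds shown leave open whether the shift follows the nitrogen itself or the two methyl groups it carries, a question that an unsubstituted amino group or a hydroxyl at the same carbon would address. As far as these compounds go, it also remains open whether a halogen such as fluorine, or a longer chain such as ethoxy, would stay with hydrogen and methoxy or move with dimethylamino.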